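The source may hold more compounds than are shown below. What is called first, only, known or untested is meant among the compounds shown, and "the series" means these compounds.

Compound 1 `CCCCCCCCOP(=O)(O)OCCSC(=S)N1CCCC1`: 28300 nM
Compound 2 `CCCCCCCCCCOP(=O)(O)OCCSC(=S)N1CCCC1`: > 100000 nM (a limit)

Going by the values given here, in an ADME assay on HEK293 cells (Homo sapiens) for inhibition, read by MTT assay, with stated times of 18 h and 4 h (on this read-out lower numbers stand for stronger inhibition and higher numbers for weaker inhibition), compound 1 gives 28300 nM, the only true number in this small set. Compound 2 reads > 100000 nM, which is a limit of the assay and not a number. Compound 1 can therefore be placed only against that limit, with no wider series to rank it in.

Compound 3 `CCCCCCCCOP(=O)(O)OCCSC(=S)N1CCN(C)CC1` keeps the core of compound 1 and changes one group: 4-methylpiperazin-1-yl in place of pyrrolidin-1-yl on a thiocarbonyl carbon. Among the compounds with values here, the single measured step, an at least 3.5-fold higher number from compound 1 to compound 2 (0.54 log units; beyond the scatter), lies beyond the scatter, but it alters the saturated chain and not the group on the thiocarbonyl carbon. It therefore gives no direction for this change, and only shows that one edit in this family can move the read-out noticeably. With no measured guide at this place, the value of compound 1 remains the natural anchor, and the range must stay wide.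

The estimated step is a 1.1-fold higher number from compound 1 to compound 3 (0.03 log units; within the scatter), so no expected shift beyond the scatter in this assay is predicted in either direction. For compound 3 the estimated value is 30000 nM, with an expected range from 10000 nM to 90000 nM.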

Compound 3, half-maximal inhibitory concentration: 86000 nM
For compound 3 the middle estimate is 2.9-fold (0.46 log units) below the measured one; the range from low to high includes it.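

The group on the thiocarbonyl carbon matters in this assay: 4-methylpiperazin-1-yl in place of pyrrolidin-1-yl gives a 3.0-fold higher number from compound 1 to compound 3 (0.48 log units; beyond the scatter). Going by these compounds alone, until now, the only measured edit lay in the saturated chain, so this is the first sign that the other end of the molecule also affects the read-out, and here the change means weaker inhibition. The swap alters several things at once, replacing a five-membered ring with a six-membered ring, adding a second ring nitrogen and bringing in a methyl group, and this single step cannot show which of these matters.

Piperidin-1-yl, which has the six-membered ring without the second nitrogen, and piperazin-1-yl, which has both ring nitrogens without the methyl, would help separate these changes, but whether either would read closer to compound 1 or to compound 3 remains open. Compound 2 carries a limit of the assay and not a number, so the true size of the change in the saturated chain also stays unknown, and the two edits cannot be ranked against each other: the limit of > 100000 nM in this assay, at which 1 of the 3 values shown sits.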